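Acetyl to Methoxycarbonyl: What Compound 3 Should Tolerate

A few compounds are considered here, and "the series" means these few. Any claim that something is new, unique, unknown or untested is made for them only; others in the source may bear on it.

In an ADME assay on MT2 cells (Homo sapiens) for cytotoxicity, read by XTT assay, with a stated time of 4 days (a higher number here means that more compound is tolerated, a lower number that less compound is tolerated), compound 1 `Cc1nc2c(c(-c3cc(F)c4c(c3C)CCCO4)c1[C@H](OC(C)(C)C)C(=O)O)CN(CCCc1cccc(F)c1)CC2` gives > 40000 nM, which is a limit of the assay rather than a measured number. Compound 2 `CC(=O)N1CCc2nc(C)c(C(OC(C)(C)C)C(=O)O)c(-c3ccc(C)cc3)c2C1` also reaches > 40000 nM, again a limit. Both measured values therefore sit at the limit of > 40000 nM in this assay, at which 2 of the 2 values shown sit. Compound 3 `COC(=O)N1CCc2nc(C)c(C(OC(C)(C)C)C(=O)O)c(-c3ccc(C)cc3)c2C1` differs from compound 2 by methoxy in place of methyl on a carbonyl carbon, the change reading acetyl to methoxycarbonyl when cut one bond further out. With both measured compounds at the limit, no step beyond the usual scatter is expected. The step expected is a number no higher from compound 2 to compound 3 (the limit leaves the size open). Compound 3 is expected to give about 40000 nM, most likely between 20000 nM and 80000 nM.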

Compound 3, half-maximal cytotoxic concentration: > 40000 nM
Compound 3: only a limit was reported; the forecaster's own chance of this, stated with the estimate: 85%; the middle value lies on the limit itself.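

Compound 2 and compound 3 both give a limit rather than a number, so no step between them can be read: the limit of > 40000 nM in this assay, at which 3 of the 3 values shown sit.

The compounds shown leave open what concentration each one actually tolerates, and whether methoxy in place of methyl on a carbonyl carbon changes it.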